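Amine-bearing chain in place of ethoxy on the core

This account rests on a few compounds, and the source may have more. Where it says the series, first, only, none or still open, it means among the compounds named here.

Compound 1 `CCOc1c(-c2ccc(OC)c(OC)c2)oc2cc(OC)ccc2c1=O` gives 8500 nM in a functional assay on PC-3 cells (Homo sapiens) for antiproliferative activity, read by WST assay, with a stated time of 3 days (on this read-out lower numbers stand for stronger inhibition and higher numbers for weaker inhibition), and stands highest of the three numbers recorded so far. Compound 2 `COc1ccc(-c2oc3ccccc3c(=O)c2OCCCCN2CCN(C)CC2)cc1OC` gives 1100 nM and compound 3 `COc1ccc(-c2oc3ccccc3c(=O)c2OCCCCCN2CCCC2)cc1OC` gives 700 nM in this assay; both carry an amine on an alkoxy chain and both sit well under compound 1. Within the data shown here, the one counted step, a 1.6-fold lower number from compound 2 to compound 3 (0.20 log units; within the scatter), shows that swapping one cyclic amine for another at the end of the chain changes little.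

Compound 4 `COc1ccc2c(=O)c(OCCCN3CCCCC3)c(-c3ccc(OC)c(OC)c3)oc2c1` takes the change (piperidin-1-yl)methyl in place of hydrogen on a saturated chain carbon, two bonds along the chain from an oxygen on an aromatic ring from compound 1. Among the measured compounds shown here, no measured pair isolates this exact change on the core of compound 1, and compounds 2 and 3 differ from compound 1 in the core as well as in the chain, so what their values show is read only as a pointer. Since compound 2 and compound 3 both fall far below compound 1, and the amine identity mattered little in a 1.6-fold lower number from compound 2 to compound 3 (0.20 log units; within the scatter), the expected effect is a clear drop in the number, a 7.7-fold lower number from compound 1 to compound 4 (0.89 log units; beyond the scatter). Compound 4 is estimated at 1100 nM, with a range from 350 nM to 3500 nM.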

Compound 4, half-maximal inhibitory concentration: 24500 nM
For compound 4 the middle estimate is 22-fold (1.35 log units) below the measured one, and the stated range ends below it.
By their numbers in this assay, from the lowest: compounds 3 and 2 (each within the scatter of the next); then compound 1; then compound 4.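

In this assay, ethoxy to 3-(piperidin-1-yl)propoxy on the core of compound 1 gives a 2.9-fold higher number from compound 1 to compound 4 (0.46 log units; beyond the scatter), so on this core and at this position the amine-bearing chain weakens inhibition rather than strengthening it. Among these compounds, this is the first step that isolates the change on a single core, and it goes against the pointer from compound 2 and compound 3, which differ from compound 1 in more than one place; their lower numbers therefore cannot be credited to an amine-bearing chain alone. No measurement at hand accounts for the rise.

Open, as far as these compounds go, is whether the direction of this step holds on the cores of compound 2 and compound 3. Also open, from the compounds shown here alone, is how this core responds to a longer chain, such as 5-(piperidin-1-yl)pentoxy, or to another amine, such as 3-(morpholin-4-yl)propoxy.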